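The source may hold more compounds than are shown below. What is called first, only, known or untested is meant among the compounds shown, and "the series" means these compounds.

Working notes on the series. Compound 1 `Nc1cc(N)c2nc(-c3ccccc3)c(Oc3ccc(Cl)c(Cl)c3)nc2c1` carries a 3,4-dichlorophenoxy group on the shared core; in a functional assay on SK-MEL-2 cells (Homo sapiens) for inhibition, read by sulforhodamine B assay, with a stated time of 48 h (a higher number here means that more compound is tolerated, a lower number that less compound is tolerated), compound 1 gives 89100 nM. Compound 2 `Nc1cc(N)c2nc(-c3ccccc3)c(NCc3ccc(F)cc3)nc2c1` carries a (4-fluorobenzyl)amino group in that place. In this assay compound 2 gives only a limit, < 100000 nM. Compound 3 `COc1ccc(Sc2nc3cc(N)cc(N)c3nc2-c2ccccc2)cc1` carries a (4-methoxyphenyl)sulfanyl group there. In this assay compound 3 likewise gives only a limit, < 100000 nM. As far as these compounds go, the steps a step that the limit leaves unreadable from compound 1 to compound 2 and a step that the limit leaves unreadable from compound 1 to compound 3 cannot be sized, nor can a step that the two limits leave unreadable from compound 2 to compound 3; with the limit of < 100000 nM in this assay, at which 2 of the 3 values shown sit, the standing of compound 3 against compound 1 stays open. Compound 4 `Nc1cc(N)c2nc(-c3ccccc3)c(Sc3ccc(Cl)c(Cl)c3)nc2c1` differs from compound 3 by 3,4-dichlorophenyl in place of 4-methoxyphenyl on a sulfur. For the measured compounds named here, no measured step isolates this exchange of the aryl group on sulfur; the measured steps swap the whole side group and each has a limit at one end. Compound 1 does hold the same 3,4-dichlorophenyl group, on oxygen, and returns a number. For compound 4 in this assay a value near 80000 nM is expected, between 25000 nM and 200000 nM. The expected step that the limit leaves unreadable from compound 3 to compound 4 is therefore judged small and of uncertain direction.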

Compound 4, concentration lethal to 50% of the cells: < 100000 nM
Compound 4: a limit, no number; the forecaster's own chance of this, stated with the estimate: 45%; the middle value lies beyond the limit too.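

In this assay, for the compounds shown here, compound 4 gives only a limit, < 100000 nM, so no new step to compound 4 from compound 1, compound 2 or compound 3 can be read. How compound 2, compound 3 and compound 4 stand against compound 1 and against one another stays open, with one boundary shared: the limit of < 100000 nM in this assay, at which 3 of the 4 values shown sit.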